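A few compounds are considered here, and "the series" means these few. Any claim that something is new, unique, unknown or untested is made for them only; others in the source may bear on it.

Measured compounds in an assay on LtK cells with ATP-sensitive inward rectifier potassium channel 11 (Homo sapiens) as the target; on this read-out lower numbers stand for an effect already at smaller amounts and higher numbers for an effect only at larger amounts of compound:
Compound 1 `N#Cc1cccc(C(=O)Nc2c(C(O)(C(F)(F)F)C(F)(F)F)ccc3ccccc23)c1` gives 12 nM.
Compound 2 `O=C(Nc1c(C(O)(C(F)(F)F)C(F)(F)F)ccc2ccccc12)c1ccc(Cl)cc1` gives 570 nM.
Compound 3 `O=C(Nc1c(C(O)(C(F)(F)F)C(F)(F)F)ccc2ccccc12)c1cccnc1` gives 60 nM.

Compound 3 sits second of the three numbers in this assay, with compound 1 nearest and compound 2 furthest from it. The next compound, compound 4 `O=C(Nc1c(C(O)(C(F)(F)F)C(F)(F)F)ccc2ccccc12)c1cccs1`, differs from compound 3 only in the group on the carbonyl carbon: thiophen-2-yl in place of pyridin-3-yl on a carbonyl carbon.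

The three steps already seen all change the same group on the carbonyl carbon and all lie beyond the scatter: a 48-fold higher number from compound 1 to compound 2 (1.68 log units; beyond the scatter), a 5.0-fold higher number from compound 1 to compound 3 (0.70 log units; beyond the scatter) and a 9.5-fold lower number from compound 2 to compound 3 (0.98 log units; beyond the scatter). So swapping this aryl group has moved this assay by modest to large amounts in both directions, and no measured step covers a five-membered ring. The expectation for compound 4 is therefore a modest step in this assay, most likely towards a higher number, given as a 2.5-fold higher number from compound 3 to compound 4 (0.40 log units; beyond the scatter). Compound 4 is estimated at 150 nM, with a range from 40 nM to 600 nM.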

Compound 4, half-maximal effective concentration: 12 nM
For compound 4 the middle estimate is 13-fold (1.10 log units) above the measured one; the measured number lies below the stated range.
By their numbers in this assay, from the lowest: compounds 1 and 4 (each within the scatter of the next); then compound 3; then compound 2.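

Working notes on the group on the carbonyl carbon in this assay: a five-membered aromatic ring is accepted here, with thiophen-2-yl in place of pyridin-3-yl giving a 5.0-fold lower number from compound 3 to compound 4 (0.70 log units; beyond the scatter) and thiophen-2-yl in place of 4-chlorophenyl giving a 48-fold lower number from compound 2 to compound 4 (1.68 log units; beyond the scatter). Thiophen-2-yl in place of 3-cyanophenyl gives no change at the digits printed from compound 1 to compound 4 (within the scatter), so in this pair a number at this level does not depend on the nitrile, which compound 4 lacks. Nothing available explains these differences between the aromatic rings.

Open, going by these compounds, is whether the result extends to other five-membered rings, such as furan-2-yl or thiazol-2-yl, or is particular to thiophen-2-yl. Also open, on these data alone, are substituents on the thiophene, such as a nitrile or a chlorine, and non-aromatic groups on the carbonyl carbon, such as cyclopropyl.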